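This account rests on a few compounds, and the source may have more. Where it says the series, first, only, none or still open, it means among the compounds named here.

Measured compounds in a functional assay on brain (Rattus norvegicus, strain Wistar) for inhibition; a lower number here means a stronger inhibitor, a higher number a weaker inhibitor:
- compound 1, `COc1cccc(/C=C2\COc3cc(OC)ccc3C2=O)c1`: > 100000 nM
- compound 2, `CCOc1ccc2c(c1)OC/C(=C\c1ccc(O)c(O)c1)C2=O`: 11900 nM
- compound 3, `CCCOc1ccc2c(c1)OC/C(=C\c1ccc(O)c(O)c1)C2=O`: 11400 nM

Compound 1 gives only a limit in this assay, > 100000 nM, and not a measured number. Compound 2 and compound 3 share the same core and both carry the catechol side; the step of a 1.0-fold lower number from compound 2 to compound 3 (0.02 log units; within the scatter) shows that lengthening the ethyl to a propyl on the aromatic oxygen left the number essentially unchanged. So compound 3 sits together with compound 2 inside the usual scatter, with no measured number apart from these two.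

Compound 4, `CCCCOc1ccc2c(c1)OC/C(=C\c1ccc(O)c(O)c1)C2=O`, extends the chain once more: methyl in place of hydrogen on a saturated chain carbon, three bonds along the chain from an oxygen on an aromatic ring, that is propyl to butyl. Going by the values given here, the only step that bears on it is the one from compound 2 to compound 3, which was flat, so for compound 4 the expected step of a 1.0-fold lower number from compound 3 to compound 4 (0.02 log units; within the scatter) is likewise no change beyond the scatter. In this assay compound 4 is therefore estimated at 11000 nM, with a range from 4000 nM to 30000 nM.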

Compound 4, half-maximal inhibitory concentration: 11000 nM
Compound 4: middle estimate and measured number agree at the digits printed; low and high end bracket the measured number.
By their numbers in this assay, from the lowest: compounds 4, 3 and 2 (each within the scatter of the next). At a limit, above all of these: compound 1.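

Until now, only one lengthening of the chain on the aromatic oxygen could be read; this result adds a second in the same series and a span over both. In this assay the change from propyl to butyl gives a 1.0-fold lower number from compound 3 to compound 4 (0.02 log units; within the scatter), and the whole extension from ethyl to butyl gives a 1.1-fold lower number from compound 2 to compound 4 (0.03 log units; within the scatter), so neither the last added carbon nor the longer span moves the number beyond the scatter. Across compounds 2, 3 and 4, then, the chain length at this place makes no readable difference, and nothing measured here explains that flatness.

Still open, on these data alone, is whether a longer chain such as hexyl, or a chain ending in an amine or a carboxylic acid, would leave the number equally unchanged. What the catechol side contributes also cannot be read, since compound 1 differs from these compounds in more than one place.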